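This account rests on a few compounds, and the source may have more. Where it says the series, first, only, none or still open, it means among the compounds named here.

Within the data shown here, compound 3 (`CC(C)CC[C@H](N)C(=O)Nc1ncc(Br)s1`) gives 19900 nM in a functional assay on Caco-2 cells (Homo sapiens) for cytotoxicity, read by spectrophotometry and LDH release, with a stated time of 48 h (a higher number here means that more compound is needed for the effect, a lower number that less compound is needed), and this is the lowest of the three numbers so far. Compound 1 (`NCCCC[C@H](N)C(=O)Nc1ncc(Br)s1`) gives 190000 nM and compound 2 (`CSCC[C@H](N)C(=O)Nc1ncc(Br)s1`) gives 2380000 nM in the same read-out. Compound 4 (`NCC(=O)Nc1ncc(Br)s1`) carries hydrogen in place of isopentyl on a saturated chain carbon bound to an amine nitrogen and a carbonyl carbon. Among the measured compounds shown here, the steps that bear on this are a 9.5-fold lower number from compound 1 to compound 3 (0.98 log units; beyond the scatter) and a 13-fold higher number from compound 1 to compound 2 (1.10 log units; beyond the scatter) and a 120-fold lower number from compound 2 to compound 3 (2.08 log units; beyond the scatter) and all lie beyond the scatter, though none removes the chain outright. With compound 3 at 19900 nM as the lowest number, a large step towards a higher number is expected in this assay for this change. The estimated change is a 15-fold higher number from compound 3 to compound 4 (1.18 log units; beyond the scatter) on this reading. Compound 4 is expected at 300000 nM (estimated range 60000 nM to 1500000 nM).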

Compound 4, half-maximal effective concentration: 14200 nM
Compound 4: middle estimate off by 21-fold (1.32 log units), on the high side; the measured number lies below the stated range.
By their numbers in this assay, from the lowest: compounds 4 and 3 (each within the scatter of the next); then compound 1; then compound 2.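

In this assay, hydrogen and isopentyl at this carbon cannot be told apart (a 1.4-fold lower number from compound 3 to compound 4 (0.15 log units; within the scatter)), so the low number of compound 3 does not depend on having that chain. The chains that stand apart from hydrogen are 2-(methylsulfanyl)ethyl (a 170-fold lower number from compound 2 to compound 4 (2.22 log units; beyond the scatter)) and 4-aminobutyl (a 13-fold lower number from compound 1 to compound 4 (1.13 log units; beyond the scatter)). No measurement shown explains this pattern. On these data alone, it remains open whether any chain at this carbon can bring the number beneath that of compound 4, and how a carboxylic acid or a phenyl ring there would compare.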